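The compounds below may be only part of what the source reports. "The series", "measured", "known", "first", "only" and "open" are said of these compounds alone.

Measured compounds:
- compound 1, `C=CNCc1cc(-c2c(C(=O)NCC)noc2-c2cc(C(C)C)c(O)cc2O)on1`, gives 121 nM in a functional assay on HCT-116 cells (Homo sapiens) for inhibition; a higher number here means a weaker inhibitor, a lower number a stronger inhibitor
- compound 2, `CCNC(=O)c1noc(-c2cc(C(C)C)c(O)cc2O)c1-c1cc(CN2CCCCC2)no1`, gives 93 nM in this assay

Of the two numbers, compound 1 has the higher one, although the gap to compound 2 is within the scatter. The step from compound 1 to compound 2 was a 1.3-fold lower number from compound 1 to compound 2 (0.11 log units; within the scatter), so swapping the group on that saturated chain carbon made no real difference.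

Compound 3, `CCNC(=O)c1noc(-c2cc(C(C)C)c(O)cc2O)c1-c1cc(C(N)=O)no1`, has not been measured yet. It differs from compound 1 in this way: carbamoyl in place of (vinylamino)methyl on an aromatic carbon. Going by the values given here, this is not the same kind of change as the one between compound 1 and compound 2, since here the chain carbon itself goes and a carbamoyl sits directly on the ring. Among the compounds with values here, the one measured step therefore bears on it only loosely, showing that this position tolerated one swap without effect.

The step from compound 1 to compound 3 is expected to be a 1.2-fold higher number from compound 1 to compound 3 (0.09 log units; within the scatter), with no firm direction. Compound 3 is estimated at 150 nM, within 50 nM to 500 nM.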

Compound 3, half-maximal inhibitory concentration: 79 nM
Compound 3: the middle estimate sits 1.9-fold (0.28 log units) above what was measured, and the stated range covers the measured number.
By their numbers in this assay, from the lowest: compounds 3, 2 and 1 (each within the scatter of the next).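

In this assay a carbamoyl set directly on the aromatic carbon gives a 1.5-fold lower number from compound 1 to compound 3 (0.19 log units; within the scatter) and also a 1.2-fold lower number from compound 2 to compound 3 (0.07 log units; within the scatter) when the (piperidin-1-yl)methyl group is the one replaced. The earlier step only changed what hung from the saturated chain carbon, whereas here that carbon and its amine nitrogen both go, and the number still does not move beyond the scatter, so this place next to the ring nitrogen accepts all three groups shown equally well. Nothing available explains this tolerance.

All three compounds lie within the scatter of one another, so none of them shows what would shift the number at this place. From the compounds shown here alone, whether a carboxylic acid, a nitrile or a longer chain ending in a primary amine would also leave it unchanged remains open.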